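Cyano to Carbamoyl: Expected Cytotoxicity of Compound 3

A few compounds are considered here, and "the series" means these few. Any claim that something is new, unique, unknown or untested is made for them only; others in the source may bear on it.

Measured compounds:
compound 1, `Cc1cccc(-c2nc3cc(-c4nc5cc(C#N)ccc5[nH]4)ccc3[nH]2)c1`, 860 nM
compound 2, `N#Cc1ccc2[nH]c(-c3ccc4[nH]c(-c5ccc6ccccc6c5)nc4c3)nc2c1`, 130 nM

For the measured compounds named here, in a functional assay on RPMI 8402 cells (Homo sapiens) for cytotoxicity (on this read-out higher numbers stand for weaker inhibition and lower numbers for stronger inhibition), compound 1 gives 860 nM, the highest of the two numbers; its only neighbour is compound 2, with 130 nM, and the single measured step, a 6.6-fold lower number from compound 1 to compound 2 (0.82 log units; beyond the scatter), changes a different part of the shared core.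

Compound 3, `Cc1cccc(-c2nc3cc(-c4nc5cc(C(N)=O)ccc5[nH]4)ccc3[nH]2)c1`, carries carbamoyl in place of cyano on an aromatic carbon. No measured step touches this position, so nothing shown bears directly on it. Compound 3 is therefore expected to give 1000 nM, within 300 nM to 3500 nM. This estimate means a step of a 1.2-fold higher number from compound 1 to compound 3 (0.07 log units; within the scatter), not expected to exceed the scatter.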

Compound 3, half-maximal inhibitory concentration: 8200 nM
For compound 3 the middle estimate is 8.2-fold (0.91 log units) below the measured one; measured number outside the range, above it.
By their numbers in this assay, from the lowest: compound 2; then compound 1; then compound 3.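

In this assay, the aromatic carbon that carries cyano in compound 1 proves sensitive to its substituent: carbamoyl in place of cyano gives a 9.5-fold higher number from compound 1 to compound 3 (0.98 log units; beyond the scatter). For the compounds shown here, the earlier step changed another part of the shared core, so this is the first sign that this position matters, and here the change goes towards weaker inhibition. No evidence at hand accounts for this step.

Going by these compounds, how a carboxylic acid or an amine would fare at this position remains open. So does whether the same step would appear with the naphthalen-2-yl group of compound 2.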